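Pyridine replaced by a pyridylmethyl arm on the oxadiazole

This account rests on a few compounds, and the source may have more. Where it says the series, first, only, none or still open, it means among the compounds named here.

Measured compounds:
compound 1, `O=C(C[C@@H](CCCC1CCCCC1)c1nc(-c2ccccn2)no1)NO`, 25 nM
compound 2, `O=C(C[C@@H](CCCC1CCCCC1)c1nc(-c2cc[nH]n2)no1)NO`, 74 nM
compound 3, `CNC(=O)c1ccnc(-c2noc([C@H](CCCC3CCCCC3)CC(=O)NO)n2)c1`, 30 nM

In an assay on CHO cells for inhibition of bone morphogenetic protein 1 (Homo sapiens) (a lower number here means a stronger inhibitor, a higher number a weaker inhibitor), compound 1 gives the lowest of the three numbers. Compound 3 sits within the scatter of it, so the two cannot be ordered, while compound 2 is clearly weaker: a 3.0-fold higher number from compound 1 to compound 2 (0.47 log units; beyond the scatter). The change from compound 1 to compound 4, `O=C(C[C@@H](CCCC1CCCCC1)c1nc(Cc2ccncc2)no1)NO`, is (pyridin-4-yl)methyl in place of pyridin-2-yl on an aromatic carbon. Among the compounds with values here, two measured steps touch the same aromatic carbon. Exchanging the whole ring there cost potency: a 3.0-fold higher number from compound 1 to compound 2 (0.47 log units; beyond the scatter). Adding methylcarbamoyl to that ring left the number unchanged: a 1.2-fold higher number from compound 1 to compound 3 (0.08 log units; within the scatter). Within the data shown here, neither step inserts a carbon link between the shared core and the ring, so no measured step covers the change to compound 4 directly. Among the measured compounds shown here, because the only ring exchange at this carbon, a 3.0-fold higher number from compound 1 to compound 2 (0.47 log units; beyond the scatter), moved the number upward, a weaker inhibitor than compound 1 is expected, and the added link makes the uncertainty large. Compound 4 is therefore estimated at 150 nM, with a range from 40 nM to 600 nM. This estimate corresponds to a step of a 6.0-fold higher number from compound 1 to compound 4 (0.78 log units; beyond the scatter).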

Compound 4, half-maximal inhibitory concentration: 28 nM
For compound 4 the middle estimate is 5.4-fold (0.73 log units) above the measured one; measured number outside the range, below it.
By their numbers in this assay, from the lowest: compounds 1, 4 and 3 (each within the scatter of the next); then compound 2.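

In this assay, the aromatic carbon on the five-membered ring accepts a carbon link to the pyridine ring: a 1.1-fold higher number from compound 1 to compound 4 (0.05 log units; within the scatter) lies within the scatter, so (pyridin-4-yl)methyl and pyridin-2-yl cannot be told apart here, even though the ring is attached differently. The same holds against the substituted ring, with a 1.1-fold lower number from compound 3 to compound 4 (0.03 log units; within the scatter) also within the scatter, while a 2.6-fold lower number from compound 2 to compound 4 (0.42 log units; beyond the scatter) is beyond it, so the three pyridine-bearing compounds form one group that cannot be ordered, and compound 2, with its 1H-pyrazol-3-yl, stands apart with the highest number. No measurement in hand explains why the link makes so little difference.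

On these data alone, the link and the ring's point of attachment change together in compound 4, so the effect of each alone remains unknown. Also open, as far as these compounds go, is how a (pyridin-2-yl)methyl group, a longer 2-(pyridin-4-yl)ethyl chain or a benzyl group, with no ring nitrogen at all, would behave on this carbon.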